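The source may hold more compounds than are shown below. What is called first, only, known or untested is meant among the compounds shown, and "the series" means these compounds.

In an assay on membranes from spleen (Cavia porcellus) for binding affinity to leukotriene B4 receptor 1 (Homo sapiens) (a lower number here means a stronger inhibitor, a higher number a weaker inhibitor), compound 1 `O=C(O)CCCCCOc1cc(-c2ccccc2)c2ccccc2n1` gives 700 nM, and compound 2 `CC(C)(CCCCOc1cc(-c2ccccc2)c2ccccc2n1)C(=O)O` gives 183 nM, the lowest of the two numbers after a 3.8-fold lower number from compound 1 to compound 2 (0.58 log units; beyond the scatter). Compound 3 `c1ccc(-c2cc(OCCCCCc3nnn[nH]3)nc3ccccc23)cc1` brings the change ((1H-tetrazol-5-yl)methyl in place of 1-carboxy-1-methylethyl on a saturated chain carbon, four bonds along the chain from an oxygen on an aromatic ring). Among the compounds with values here, no measured pair shows an acid giving way to a tetrazole; the one step on record concerns only the two methyl groups that now leave, and that step, a 3.8-fold lower number from compound 1 to compound 2 (0.58 log units; beyond the scatter), was modest. Giving those methyl groups back and swapping the acid is therefore expected to move the number upward by about a 2.7-fold higher number from compound 2 to compound 3 (0.44 log units; beyond the scatter). For compound 3 the estimate in this assay is 500 nM, within 150 nM to 1600 nM.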

Compound 3, half-maximal inhibitory concentration: 500 nM
For compound 3 middle estimate and measured number coincide at the digits printed; the range from low to high includes it.
By their numbers in this assay, from the lowest: compound 2; then compounds 3 and 1 (each within the scatter of the next).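

In this assay, 1H-tetrazol-5-yl in place of carboxy, five bonds along the chain from an oxygen on an aromatic ring, gives a 1.4-fold lower number from compound 1 to compound 3 (0.15 log units; within the scatter), so on the unbranched chain the two groups cannot be told apart. The step of a 2.7-fold higher number from compound 2 to compound 3 (0.44 log units; beyond the scatter) removes the two methyl groups along with the acid, and compound 3 does not keep the number of compound 2. Nothing on record explains either step.

The compounds shown leave open whether a tetrazole carrying those two methyl groups would match compound 2. Going by these compounds, a longer chain or a sulfonamide at the chain end also remains open.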